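A few compounds are considered here, and "the series" means these few. Any claim that something is new, unique, unknown or untested is made for them only; others in the source may bear on it.

Measured compounds:
compound 1 `O=c1ccoc2cc(OCc3cn(Cc4ccc(F)cc4)nn3)ccc12` — 14400 nM
compound 2 `O=c1ccoc2cc(OCc3cn(Cc4ccc(Br)cc4)nn3)ccc12` — 96400 nM
compound 3 `O=c1ccoc2cc(OCc3cn(Cc4ccc([N+](=O)[O-])cc4)nn3)ccc12` — > 100000 nM

In a functional assay on QGY7701 cells (Homo sapiens) for cytotoxicity, read by MTT assay, with a stated time of 48 h (on this read-out higher numbers stand for weaker inhibition and lower numbers for stronger inhibition), compound 1 gives 14400 nM. Compound 2 gives 96400 nM, a change of a 6.7-fold higher number from compound 1 to compound 2 (0.83 log units; beyond the scatter). For compound 3 the assay reports only a limit, > 100000 nM; this is the limit of > 100000 nM in this assay, at which 1 of the 3 values shown sits. Compound 3 therefore stands at the weak end of what is shown, and its position relative to compound 2 is unresolved: the step of an at least 1.0-fold higher number from compound 2 to compound 3 (0.01 log units; that floor lies within the scatter) is a floor that lies within the scatter, while the step of an at least 6.9-fold higher number from compound 1 to compound 3 (0.84 log units; beyond the scatter) is beyond it.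

Compound 4 `N#Cc1cccc(Cn2cc(COc3ccc4c(=O)ccoc4c3)nn2)c1` differs from compound 3 by 3-cyanophenyl in place of 4-nitrophenyl on a saturated chain carbon bound to an aromatic nitrogen. Among the compounds with values here, no measured step exchanges the nitro group for a nitrile, and none moves a substituent around the ring, so the bearing steps are only those ending at compound 3. Compound 3 is a limit, so the step to compound 4 can only be bounded below. With all three measured values weak, compound 4 is expected to lie somewhere between compound 1 and the limit, an estimated step of an at least 2.0-fold lower number from compound 3 to compound 4 (0.30 log units; that floor lies within the scatter). Compound 4 is thus estimated at 50000 nM, within 12000 nM to 100000 nM.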

Compound 4, half-maximal inhibitory concentration: 24400 nM
For compound 4 the middle estimate is 2.0-fold (0.31 log units) above the measured one; the range from low to high includes it.
By their numbers in this assay, from the lowest: compounds 1 and 4 (each within the scatter of the next); then compound 2. At a limit, above all of these: compound 3.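

Exchanging 4-nitrophenyl for 3-cyanophenyl on a saturated chain carbon bound to an aromatic nitrogen lowers the number in this assay, with an at least 4.0-fold lower number from compound 3 to compound 4 (0.61 log units; beyond the scatter), so a ring bearing a nitrogen-containing group need not stand at the weak end. Against the 4-bromophenyl group the exchange gives a 4.0-fold lower number from compound 2 to compound 4 (0.60 log units; beyond the scatter), while against 4-fluorophenyl it gives a 1.7-fold higher number from compound 1 to compound 4 (0.23 log units; within the scatter), which places the fluoro and cyano compounds level and shows that the low number here is not confined to a halogen. The first of these steps is only a floor, as compound 3 stands at a limit: the limit of > 100000 nM in this assay, at which 1 of the 4 values shown sits.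

The name of the group and its place on the ring change together, so the effect of the nitrile cannot be separated from that of its position. On these data alone, whether 4-cyanophenyl, or a ring carrying an amine or a carboxylic acid, would give a lower number stays open.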